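Dihydropyridine Ester Series: From Compound 3 to Compound 4

This account rests on a few compounds, and the source may have more. Where it says the series, first, only, none or still open, it means among the compounds named here.

Of the compounds shown here, three share a common core and have been tested in a functional assay (muscle tissue) with Cavia porcellus as the target; a higher number here means that more compound is needed for the effect, a lower number that less compound is needed. Compound 1 `COC(=O)C1=C(C)N=C(C)/C(=C(\O)OC)C1c1ccc(F)cc1` gives 129 nM. Compound 2 `COC(=O)C1=C(C)N=C(C)/C(=C(\O)OC)C1c1ccc(I)cc1` gives 22900 nM. Compound 3 `COC(=O)C1=C(C)N=C(C)/C(=C(\O)OC)C1c1ccccc1Br` gives 7.59 nM, the lowest of the three numbers; the step of a 17-fold lower number from compound 1 to compound 3 (1.23 log units; beyond the scatter) and the step of a 3000-fold lower number from compound 2 to compound 3 (3.48 log units; beyond the scatter) both lie beyond the scatter, so compound 3 is the most potent measured compound.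

Compound 4 `COC(=O)C1=C(C)N=C(C)/C(=C(\O)OC)C1c1ccc(Cl)cc1Cl` is not yet measured. It differs from compound 3 by 2,4-dichlorophenyl in place of 2-bromophenyl on a saturated ring carbon. Going by the values given here, two measured steps bear on this change. The step of a 17-fold lower number from compound 1 to compound 3 (1.23 log units; beyond the scatter) shows that a halogen placed as in 2-bromophenyl gave a far lower number than one placed as in 4-fluorophenyl. The step of a 180-fold higher number from compound 1 to compound 2 (2.25 log units; beyond the scatter) shows that a larger halogen placed as in 4-iodophenyl gave a much higher number. Compound 4 keeps a halogen in the favourable place but adds a second one where compound 2 was penalised, so a moderate rise is expected for compound 4, estimated at 40 nM with a range of 8 nM to 300 nM, corresponding to an expected step of a 5.3-fold higher number from compound 3 to compound 4 (0.72 log units; beyond the scatter).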

Compound 4, half-maximal effective concentration: 640 nM
Compound 4: middle estimate off by 16-fold (1.20 log units), on the low side; the whole stated range lies below it.
By their numbers in this assay, from the lowest: compound 3; then compound 1; then compound 4; then compound 2.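

In this assay, keeping a halogen as in 2-bromophenyl did not preserve the low number once 2,4-dichlorophenyl took its place on the saturated ring carbon (an 84-fold higher number from compound 3 to compound 4 (1.93 log units; beyond the scatter)). The new group still stood well clear of 4-iodophenyl (a 36-fold lower number from compound 2 to compound 4 (1.55 log units; beyond the scatter)) yet gave a higher number than 4-fluorophenyl (a 5.0-fold higher number from compound 1 to compound 4 (0.70 log units; beyond the scatter)), so among these compounds it falls between the two phenyl groups with a single halogen and shows that this position also separates groups that both carry a halogen where compound 3 does. Nothing available explains these steps.

The compounds shown do not separate the effect of exchanging bromine for chlorine from that of adding a second chlorine. They also leave open how an amine or a methoxy group on the phenyl ring would compare with the halogens.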